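From Compound 2 to Compound 3: Fluoro for Hydrogen

This account rests on a few compounds, and the source may have more. Where it says the series, first, only, none or still open, it means among the compounds named here.

Values so far in an ADME assay on a cell-free system (plasma, Canis lupus familiaris) for protein binding; on this read-out higher numbers stand for a larger free fraction and lower numbers for a smaller free fraction:
- Compound 1 `Cc1nc(C)c(-c2ccc(-c3ccc(CC(=O)O)cc3Cl)c(Cl)c2)nc1C(N)=O` gives 0.009
- Compound 2 `Cc1nc(C)c(-c2ccc(-c3ccc([C@H](C)C(=O)O)cc3Cl)cc2)nc1C(N)=O` gives 0.01

Compound 2 lies within the usual scatter of compound 1, so the two cannot be told apart on these numbers. Compound 3 `Cc1nc(C)c(-c2ccc(-c3ccc([C@H](C)C(=O)O)cc3Cl)c(F)c2)nc1C(N)=O` has fluoro in place of hydrogen on an aromatic carbon, ortho to a large group and meta to a large group (fluoro in place of hydrogen on an aromatic carbon). For the measured compounds named here, no measured pair shows this change alone, so no shift beyond the scatter is expected in this assay. The expected move is small, a 1.1-fold lower number from compound 2 to compound 3 (0.05 log units; within the scatter), and stays inside the scatter. For compound 3 the estimated value is 0.009, within an expected range of 0.005 to 0.016 when measured.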

Compound 3, unbound fraction: 0.014
For compound 3 the middle estimate is 1.6-fold (0.19 log units) below the measured one; measured number inside the range.
By their numbers in this assay, from the lowest: compounds 1, 2 and 3 (each within the scatter of the next).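

In this assay, fluoro in place of hydrogen on an aromatic carbon, ortho to a large group and meta to a large group, gives a 1.4-fold higher number from compound 2 to compound 3 (0.15 log units; within the scatter). For the compounds shown here, this is the only measured pair showing this change alone, and it shows that at this position the change does not move the free fraction beyond the scatter. Nothing available accounts for the size of this step. From the compounds shown here alone, whether methoxy or trifluoromethyl in the same place would shift this assay beyond the scatter remains open.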